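This account rests on a few compounds, and the source may have more. Where it says the series, first, only, none or still open, it means among the compounds named here.

Measured so far in a functional assay on HepG2 cells (Homo sapiens) for inhibition, read by MTT assay, with a stated time of 72 h; on this read-out lower numbers stand for stronger inhibition and higher numbers for weaker inhibition:
- compound 1 `CN(C(=O)NC(=O)c1c(F)cccc1F)c1nc(C(F)(F)F)c(C(=O)N/N=C/c2cc(C(F)(F)F)cc(C(F)(F)F)c2)s1`: 6.28 ug/mL
- compound 2 `CN(C(=O)NC(=O)c1c(F)cccc1F)c1nc(C(F)(F)F)c(C(=O)N/N=C/c2cccc(C(F)(F)F)c2)s1`: 27.9 ug/mL
- compound 3 `Cc1nc(N(C)C(=O)NC(=O)c2c(F)cccc2F)sc1C(=O)N/N=C/c1cc(C(F)(F)F)cc(C(F)(F)F)c1`: 11.4 ug/mL

Compound 1 gives the lowest number of the three. Its gap to compound 3 is within the scatter (a 1.8-fold higher number from compound 1 to compound 3 (0.26 log units; within the scatter)), so no order between compound 1 and compound 3 can be claimed; its gap to compound 2 is beyond the scatter (a 4.4-fold higher number from compound 1 to compound 2 (0.65 log units; beyond the scatter)).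

Compound 4 `CN(C(=O)NC(=O)c1ccccc1F)c1nc(C(F)(F)F)c(C(=O)N/N=C/c2cc(C(F)(F)F)cc(C(F)(F)F)c2)s1` differs from compound 1 in one place: hydrogen in place of fluoro on an aromatic carbon, that is 2,6-difluorophenyl to 2-fluorophenyl. Going by the values given here, neither measured step touches this part of the shared core: the step from compound 1 to compound 2 and the step from compound 1 to compound 3 both concern a trifluoromethyl on other rings, so they bear on the new step only by showing what size of change single-group edits have produced in this assay so far. The removal of one small group here is expected to give at most a modest rise, likely within the scatter, so a 1.4-fold higher number from compound 1 to compound 4 (0.16 log units; within the scatter) is the expected step. Compound 4 is estimated at 9 ug/mL, with a range of 4 ug/mL to 25 ug/mL.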

Compound 4, half-maximal inhibitory concentration: 4.47 ug/mL
Beside the measured number, compound 4's estimate is 2.0-fold (0.30 log units) above it; the measured number falls inside the stated range.
By their numbers in this assay, from the lowest: compounds 4, 1 and 3 (each within the scatter of the next, the first and the last beyond it); then compound 2.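

The first edit on the 2,6-difluorophenyl part of compound 1, to 2-fluorophenyl, gives a 1.4-fold lower number from compound 1 to compound 4 (0.15 log units; within the scatter) in this assay. One fluoro on this ring can therefore be exchanged for hydrogen with no change that stands clear of the scatter, unlike the loss of a trifluoromethyl in the other ring, which gave a 4.4-fold higher number from compound 1 to compound 2 (0.65 log units; beyond the scatter) on the same read-out. No measured property bears on this result.

Going by these compounds, whether the remaining fluoro can also go, leaving a plain phenyl, and how a methoxy or an amine would fare on this ring, stays open. Going by these compounds alone, the fluoro edit is also seen only on the core of compound 1, so its size with the substituents of compound 2 or compound 3 is unknown.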